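Dimethoxyphenyl for bromophenyl in a Vero cell tolerance series

A few compounds are considered here, and "the series" means these few. Any claim that something is new, unique, unknown or untested is made for them only; others in the source may bear on it.

Compound 1 `COC(=O)c1cc(-c2cccc(NC(=O)c3ccc(/C=C/C(=O)c4ccccc4)cc3)c2)on1` is the parent of the set. In an ADME assay on Vero cells (Chlorocebus sabaeus) for cytotoxicity, read by MTT assay, with a stated time of 72 h (a higher number here means that more compound is tolerated, a lower number that less compound is tolerated), compound 1 reaches only a limit, > 50 ug/mL. Compound 2 `CCOc1ccc(C(=O)/C=C/c2ccc(C(=O)Nc3cccc(-c4cc(C(=O)OC)no4)c3)cc2)cc1` is carried in this assay only to a limit, > 40 ug/mL. Compound 3 `COC(=O)c1cc(-c2cccc(NC(=O)c3ccc(/C=C/C(=O)c4cccc(Br)c4)cc3)c2)on1` likewise gives only a limit in this assay, > 100 ug/mL. Among the measured compounds shown here, compound 3 therefore stands among three values that are each limits rather than numbers, and the three limits allow no comparison among the compounds. The steps a step that the two limits leave unreadable from compound 1 to compound 2, a step that the two limits leave unreadable from compound 1 to compound 3 and a step that the two limits leave unreadable from compound 2 to compound 3 cannot be sized because of the limit of > 100 ug/mL in this assay, at which 1 of the 3 values shown sits, the limit of > 40 ug/mL in this assay, at which 1 of the 3 values shown sits, and the limit of > 50 ug/mL in this assay, at which 1 of the 3 values shown sits, are each limits and not measured numbers. Compound 4 `COC(=O)c1cc(-c2cccc(NC(=O)c3ccc(/C=C/C(=O)c4ccc(OC)c(OC)c4)cc3)c2)on1` differs from compound 3 by 3,4-dimethoxyphenyl in place of 3-bromophenyl on a carbonyl carbon. The measured steps that bear on this change are all unreadable, so they give neither size nor direction, and the expected step of an at least 1.2-fold lower number from compound 3 to compound 4 (0.09 log units; that floor lies within the scatter) is therefore none beyond the scatter, with a further limit the most probable outcome. Compound 4 is thus estimated at 80 ug/mL, with a range from 40 ug/mL to 200 ug/mL.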

Compound 4, half-maximal cytotoxic concentration: > 50 ug/mL
Compound 4 was reported as a limit (the forecaster's own chance of this, stated with the estimate: 80%); the middle value is on the limit's open side.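

Compound 4, like compound 1, compound 2 and compound 3, gives only a limit in this assay, so none of its steps to those three compounds can be read. The compounds shown leave open whether exchanging the aryl group on the carbonyl carbon changes tolerance at all.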